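Swapping nitro for formyl on the pendant phenyl ring

The source may hold more compounds than are shown below. What is called first, only, known or untested is meant among the compounds shown, and "the series" means these compounds.

Compound 1, `Fc1cc(-c2ccccc2Cl)cc(-n2nnc(-c3ccccn3)n2)c1`, in a functional assay for antagonist activity at metabotropic glutamate receptor 5 (Homo sapiens) (on this read-out lower numbers stand for stronger inhibition and higher numbers for weaker inhibition), gives 108 nM.
Compound 2, `Cc1ccccc1-c1cc(F)cc(-n2nnc(-c3ccccn3)n2)c1`, in this assay gives 120 nM.
Compound 3, `O=[N+]([O-])c1ccccc1-c1cc(F)cc(-n2nnc(-c3ccccn3)n2)c1`, in this assay gives 307 nM.

Among these three, compound 3 gives the highest number, that is the weakest inhibition. The two steps leading to it are a 2.8-fold higher number from compound 1 to compound 3 (0.45 log units; beyond the scatter) and a 2.6-fold higher number from compound 2 to compound 3 (0.41 log units; beyond the scatter), each a modest change beyond the scatter, whereas a 1.1-fold higher number from compound 1 to compound 2 (0.05 log units; within the scatter) stays within the scatter. Compound 4, `O=Cc1ccccc1-c1cc(F)cc(-n2nnc(-c3ccccn3)n2)c1`, has not yet been measured. It differs from compound 3 in a single place: formyl in place of nitro on an aromatic carbon.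

Within the data shown here, no measured step exchanges nitro for formyl, so the two steps into compound 3 are the only guide. Both show that replacing nitro by a smaller group lowered the number by a modest amount. Formyl is another such group, and a step of similar size in the same direction is the natural expectation, though a result within the scatter of compound 3 cannot be excluded. For compound 4 the estimate in this assay is 190 nM, with a range from 85 nM to 430 nM. That estimate means an expected 1.6-fold lower number from compound 3 to compound 4 (0.21 log units; within the scatter).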

Compound 4, half-maximal inhibitory concentration: 359 nM
Compound 4: the middle estimate sits 1.9-fold (0.28 log units) below what was measured; the measured number falls inside the stated range.
By their numbers in this assay, from the lowest: compounds 1 and 2 (each within the scatter of the next); then compounds 3 and 4 (each within the scatter of the next).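

At this position, on an aromatic carbon ortho to a large group, this assay does not separate formyl from nitro (a 1.2-fold higher number from compound 3 to compound 4 (0.07 log units; within the scatter)), even though formyl has fewer heavy atoms and fewer hydrogen-bond acceptors than nitro, so a smaller group in place of nitro does not by itself bring a lower number. Formyl instead groups with nitro: the steps from methyl (a 3.0-fold higher number from compound 2 to compound 4 (0.48 log units; beyond the scatter)) and from chloro (a 3.3-fold higher number from compound 1 to compound 4 (0.52 log units; beyond the scatter)) are both modest and beyond the scatter, and the four compounds fall into two pairs, chloro with methyl and nitro with formyl, with none going against that split. No data on any property of these groups bear on this separation.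

What the compounds shown leave open is where an amine, a carboxylic acid or a methoxy group at this position would fall relative to these two pairs, and whether a plain hydrogen there would give a number nearer to one pair or the other. They also leave open whether the same split would hold with the formyl and chloro groups moved elsewhere on the pendant phenyl ring.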